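One Added Methyl on the Chain of Compound 3

A few compounds are considered here, and "the series" means these few. Any claim that something is new, unique, unknown or untested is made for them only; others in the source may bear on it.

Of the compounds shown here, three have been measured in a functional assay on NCI-H460 cells (Homo sapiens) for antiproliferative activity, read by MTT assay, with a stated time of 48 h; on this read-out higher numbers stand for weaker inhibition and lower numbers for stronger inhibition. Compound 3 `CCCCC1(O)C(=O)Nc2ccc(Nc3ccc(C)cc3)cc21` gives 31800 nM. That number lies within the scatter of compound 2 `CCCCCC1(O)C(=O)Nc2ccc(Nc3ccc(OC)cc3)cc21`, which gives 16200 nM. It is a higher number, beyond the scatter, than that of compound 1 `O=C1Nc2ccc(Nc3ccc(Cl)cc3)cc2/C1=C\C1CCCCC1`, which gives 13200 nM.

Compound 4 `CCCCCC1(O)C(=O)Nc2ccc(Nc3ccc(C)cc3)cc21` has not yet been measured in this assay. It departs from compound 3 by a single change: methyl in place of hydrogen on a saturated chain carbon, four bonds along the chain from a saturated ring carbon. This places methyl in place of hydrogen on a saturated chain carbon, four bonds along the chain from a saturated ring carbon.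

Within the data shown here, no two measured compounds differ in one place alone, so the size of such a step cannot be read directly from the data. Among the measured compounds shown here, the only guide is how close the measured values lie, with compound 2 at 16200 nM standing within the scatter of compound 3. A small step is therefore expected, toward a lower number if there is one, and quite possibly none beyond the scatter. The expected change is a 1.4-fold lower number from compound 3 to compound 4 (0.16 log units; within the scatter). For compound 4 the estimated value is 22000 nM, with an expected range of 11000 nM to 42000 nM.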

Compound 4, half-maximal inhibitory concentration: > 100000 nM
Compound 4: only a limit was reported (the forecaster's own chance of this, stated with the estimate: 3%); middle value at least 4.5-fold (0.65 log units) away from the limit.
By their numbers in this assay, from the lowest: compounds 1, 2 and 3 (each within the scatter of the next, the first and the last beyond it). At a limit, above all of these: compound 4.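

In this assay compound 4 gives > 100000 nM, which is a limit of the assay and not a number: the limit of > 100000 nM in this assay, at which 1 of the 4 values shown sits.

The earlier compounds shown here offered no pair differing in one place, so they could not show what this chain carbon tolerates. Methyl in place of hydrogen on a saturated chain carbon, four bonds along the chain from a saturated ring carbon, now proves to be a real step in this series, with an at least 3.1-fold higher number from compound 3 to compound 4 (0.49 log units; beyond the scatter) as its reading. The same chain also turns out to be sensitive to the other end of the molecule: methyl in place of methoxy on an aromatic carbon gives an at least 6.1-fold higher number from compound 2 to compound 4 (0.79 log units; beyond the scatter), so the change in compound 4 cannot be judged from the chain alone.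

Both steps are bounded on one side only, which leaves their true size open, and no cause for either can be read from these compounds. As far as these compounds go, whether a longer chain, or a chain ending in an amine or a carboxylic acid, would continue this loss or reverse it remains open, as does the effect of methoxy on the shorter chain of compound 3.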